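This account rests on a few compounds, and the source may have more. Where it says the series, first, only, none or still open, it means among the compounds named here.

In a functional assay on K562 cells (Homo sapiens) for antiproliferative activity, read by MTT assay, with a stated time of 48 h (a lower number here means a stronger inhibitor of growth, a higher number a weaker inhibitor of growth), compound 3 `COc1ccc(N(C)c2nc(Cl)nc3c2ncn3Cc2cc(OC)cc(OC)c2)cc1` gives 42000 nM and compound 2 `COc1ccc(N(C)c2nc(Cl)nc3c2ncn3Cc2ccc(OC)c(OC)c2)cc1` gives 27000 nM, so the two stand level within the scatter. Compound 1 `COc1ccc(N(C)c2ncnc3c2ncn3Cc2cc(OC)c(OC)c(OC)c2)cc1` gives only a limit of the assay, > 100000 nM. Compound 4 `COc1ccc(N(C)c2nc(Cl)nc3c2ncn3Cc2cc(OC)c(OC)c(OC)c2)cc1` differs from compound 3 by one change, methoxy in place of hydrogen on an aromatic carbon, ortho to two methoxy groups and para to a large group. Among the compounds with values here, the one measured step that bears on this, a 1.6-fold higher number from compound 2 to compound 3 (0.19 log units; within the scatter), rearranges the methoxy groups on that ring and stays within the scatter. No step beyond the scatter is therefore expected in this assay, and the expected step is a 1.3-fold lower number from compound 3 to compound 4 (0.12 log units; within the scatter). For compound 4 the estimated value is 32000 nM, with an expected range of 11000 nM to 90000 nM.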

Compound 4, concentration for 50% growth inhibition: 41000 nM
Compound 4: the middle estimate sits 1.3-fold (0.11 log units) below what was measured; the range from low to high includes it.
By their numbers in this assay, from the lowest: compounds 2, 4 and 3 (each within the scatter of the next). At a limit, above all of these: compound 1.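

In this assay, a third methoxy on this aromatic carbon, ortho to two methoxy groups and para to a large group, gives no readable shift: a 1.0-fold lower number from compound 3 to compound 4 (0.01 log units; within the scatter), and a 1.5-fold higher number from compound 2 to compound 4 (0.18 log units; within the scatter). Chloro in place of hydrogen on the shared core is the only new step beyond the scatter: an at least 2.4-fold lower number from compound 1 to compound 4 (0.38 log units; beyond the scatter). Compound 1 gives a limit of the assay, not a number: the limit of > 100000 nM in this assay, at which 1 of the 4 values shown sits. Still open, going by these compounds, is whether an amine, a carboxylic acid or a longer chain on this same carbon would give a step beyond the scatter.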